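This account rests on a few compounds, and the source may have more. Where it says the series, first, only, none or still open, it means among the compounds named here.

Going by the values given here, in a functional assay on Ishikawa cells (Homo sapiens) for antiproliferative activity, read by CCK-8 assay, with a stated time of 48 h (on this read-out lower numbers stand for stronger inhibition and higher numbers for weaker inhibition), compound 2 `C/C=C/C(=O)N1CC(Oc2ccc(Oc3c(-c4ccc(F)cc4)sc4cc(O)ccc34)cc2)C1` gives 9400 nM, the best defined number so far. Compound 3 `CN(C)C(=O)/C=C/CNCCOc1ccc(Oc2c(-c3ccc(F)cc3)sc3cc(O)ccc23)cc1` gives 11900 nM, and the gap is within the scatter: a 1.3-fold higher number from compound 2 to compound 3 (0.10 log units; within the scatter). Compound 1 `CNC(=O)/C=C/CN1CC(Oc2ccc(Oc3c(-c4ccc(F)cc4)sc4cc(O)ccc34)cc2)C1` reads > 25000 nM, which is a limit and not a number. Compound 4 `O=C(/C=C/CN1CC(Oc2ccc(Oc3c(-c4ccc(F)cc4)sc4cc(O)ccc34)cc2)C1)N1CCCC1` changes compound 2 on an amine nitrogen in a ring: 3-((pyrrolidin-1-yl)carbonyl)prop-2-en-1-yl in place of (prop-1-en-1-yl)carbonyl on an amine nitrogen in a ring. The step that bears most directly on this is an at least 2.6-fold lower number from compound 1 to compound 2 (0.42 log units; beyond the scatter), which exchanges a 3-(methylcarbamoyl)prop-2-en-1-yl chain for the same (prop-1-en-1-yl)carbonyl group at that place. Its reverse direction suggests weaker inhibition, so the expected step is a 2.3-fold higher number from compound 2 to compound 4 (0.37 log units; beyond the scatter), modest in size though possibly larger. For compound 4 the estimated value is 22000 nM, with an expected range of 9000 nM to 50000 nM.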

Compound 4, half-maximal inhibitory concentration: 9150 nM
For compound 4 the middle estimate is 2.4-fold (0.38 log units) above the measured one, within the range that was stated.
By their numbers in this assay, from the lowest: compounds 4, 2 and 3 (each within the scatter of the next). At a limit, above all of these: compound 1.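

On an amine nitrogen in a ring, the larger 3-((pyrrolidin-1-yl)carbonyl)prop-2-en-1-yl chain and the (prop-1-en-1-yl)carbonyl group read alike in this assay (a 1.0-fold lower number from compound 2 to compound 4 (0.01 log units; within the scatter)). A chain of this kind at this place therefore need not weaken inhibition, as compound 1 alone had suggested. The outcome turns on the amide end, with pyrrolidin-1-yl in place of methylamino on a carbonyl carbon (an at least 2.7-fold lower number from compound 1 to compound 4 (0.43 log units; beyond the scatter)), but that comparison starts from a limit and not a number: the limit of > 25000 nM in this assay, at which 1 of the 4 values shown sits.

Still open, as far as these compounds go, is whether a piperidine or morpholine amide, or a longer chain on that nitrogen, would move the number beyond the scatter of compound 2.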